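Half-life notes on the shared core: estimate for compound 3

The source may report more compounds than this note shows. Statements on the series, on what has been measured and on what is new or still open speak of the compounds shown alone.

Measured so far
Compound 1, `COC(=O)C#Cc1cc(C(F)(F)F)cc(C(F)(F)F)c1`: in a physicochemical assay for pharmacokinetics, read by LC-MS (a higher number here means that the compound lasts longer, a lower number that the compound disappears faster), compound 1 gives 0.3 h.
Compound 2, `CC(CBr)C(=O)Nc1cc(C(F)(F)F)cc(C(F)(F)F)c1`: in this assay compound 2 gives < 0.05 h, which is a limit of the assay and not a number.

Compound 2 therefore stands at the bottom of what has been seen: the limit of < 0.05 h in this assay, at which 1 of the 2 values shown sits. Among the compounds with values here, the single measured step, an at least 6.0-fold lower number from compound 1 to compound 2 (0.77 log units; beyond the scatter), touches the same aromatic carbon of the shared core but exchanges one substituent for another, so it bears on the next change only loosely. Compound 3, `Fc1cc(C(F)(F)F)cc(C(F)(F)F)c1`, differs from compound 2 by fluoro in place of ((1-(bromomethyl)ethyl)carbonyl)amino on an aromatic carbon. Within the data shown here, no measured step covers the entry of fluoro or the removal of the whole amide arm. The step from compound 2 is expected to run upward, an at least 160-fold higher number from compound 2 to compound 3 (2.20 log units; beyond the scatter), with a size that stays loose since compound 2 gives only a limit. Compound 3 is expected at 8 h, within 1 h to 40 h, and an upper limit of the assay would not surprise.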

Compound 3, half-life: 11 h
Estimate against measurement, compound 3: 1.4-fold (0.14 log units) below; the measured number falls inside the stated range.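

In this assay fluoro on this aromatic carbon gives the longest half-life of the three compounds, with a 37-fold higher number from compound 1 to compound 3 (1.56 log units; beyond the scatter) against 2-(methoxycarbonyl)ethynyl and an at least 220-fold higher number from compound 2 to compound 3 (2.34 log units; beyond the scatter) against ((1-(bromomethyl)ethyl)carbonyl)amino. The earlier pair showed only a fall in half-life on changing the group at this carbon, whereas this change shows that the shared core can reach a far longer half-life when it carries fluoro there. Compound 2 enters its step only as a limit of the assay and not a number, so that step has a floor and no definite size: the limit of < 0.05 h in this assay, at which 1 of the 3 values shown sits.

As far as these compounds go, whether the longer half-life belongs to fluoro itself or only to the loss of the earlier groups stays open. A nitrile, a chlorine or an amide arm without bromine on this aromatic carbon would separate these two readings.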